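Adding an Isopropoxy Group to a Second Core

This account rests on a few compounds, and the source may have more. Where it says the series, first, only, none or still open, it means among the compounds named here.

Three compounds have so far been measured in a functional assay on brain (Rattus norvegicus, strain Wistar) for inhibition; a lower number here means a stronger inhibitor, a higher number a weaker inhibitor:

Compound 1 `Cc1[nH]c(=O)n(C)c1-c1ccccc1` gives > 100000 nM.
Compound 2 `Cc1[nH]c(=O)n(C2CCCCC2)c1-c1ccccc1` gives 47600 nM.
Compound 3 `Cc1[nH]c(=O)n(C)c1-c1ccc(OC(C)C)cc1` gives 20400 nM.

The reported value of compound 1 is a limit of the assay and not a number (the limit of > 100000 nM in this assay, at which 1 of the 3 values shown sits). Compound 2 differs from compound 1 in one place: cyclohexyl in place of methyl on an aromatic nitrogen. That change produced an at least 2.1-fold lower number from compound 1 to compound 2 (0.32 log units; beyond the scatter). Compound 3 differs from compound 1 in a different place: isopropoxy in place of hydrogen on an aromatic carbon. That change produced an at least 4.9-fold lower number from compound 1 to compound 3 (0.69 log units; beyond the scatter).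

Compound 4 `Cc1[nH]c(=O)n(C2CCCCC2)c1-c1cccc(OC(C)C)c1` has not yet been measured. It combines the cyclohexyl group of compound 2 with an isopropoxy group on the six-membered ring, so the two cores differ as described by cyclohexyl in place of methyl on an aromatic nitrogen, and the change from compound 2 to compound 4 is isopropoxy in place of hydrogen on an aromatic carbon. Among the compounds with values here, this is the same kind of change as the one from compound 1 to compound 3, but the place is not identical: in compound 3 the new group sits para to a group of 8 heavy atoms, whereas in compound 4 it sits meta to a large group. From compound 2 to compound 4 in this assay a step of about a 4.0-fold lower number from compound 2 to compound 4 (0.60 log units; beyond the scatter) is expected, resting on the gain seen in an at least 4.9-fold lower number from compound 1 to compound 3 (0.69 log units; beyond the scatter), tempered by the different place. The estimated value for compound 4 is therefore 12000 nM, with a likely range from 4000 nM to 40000 nM.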

Compound 4, half-maximal inhibitory concentration: 10400 nM
Estimate against measurement, compound 4: 1.2-fold (0.06 log units) above; low and high end bracket the measured number.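

In this assay, within the data shown here, isopropoxy in place of hydrogen on an aromatic carbon gave a 4.6-fold lower number from compound 2 to compound 4 (0.66 log units; beyond the scatter), so this kind of change also lowered the number on the core carrying cyclohexyl, here with the new group meta to a large group and so in a different place from the one it holds in compound 3. Compound 1 gives > 100000 nM, which is a limit of the assay and not a number. The size of the step on the first core is therefore known only from one side, and the comparison changes both the core and the place of the group, so it does not show that the gain carries over from one core to the other unchanged: the same change on two cores in this assay, an at least 4.9-fold lower number (0.69 log units; beyond the scatter) from compound 1 to compound 3 and a 4.6-fold lower number (0.66 log units; beyond the scatter) from compound 2 to compound 4; the limit leaves it open whether they differ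

No single core shown here carries isopropoxy in both places, which leaves open how much the place matters by itself, separately from the change of core. Also open, going by these compounds, is whether the gain belongs to isopropoxy in particular or would extend to other groups on the same aromatic carbon, such as methoxy, a longer alkoxy chain, an amine or a carboxylic acid.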